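Swapping Trifluoromethyl for Nitro on a Benzyl Ether

The compounds below may be only part of what the source reports. "The series", "measured", "known", "first", "only" and "open" are said of these compounds alone.

Compound 1, `c1ccc(COc2ccccc2Nc2ncnc3cc4c(cc23)OCCOCCO4)cc1`, in a functional assay on SH-SY5Y cells (Homo sapiens) for antiproliferative activity, read by MTT assay, with a stated time of 72 h; on this read-out lower numbers stand for stronger inhibition and higher numbers for weaker inhibition: 93700 nM
Compound 2, `FC(F)(F)c1ccc(COc2ccccc2Nc2ncnc3cc4c(cc23)OCCOCCO4)cc1`, in this assay: > 100000 nM
Compound 3, `c1ccc(COc2cccc(Nc3ncnc4cc5c(cc34)OCCOCCO5)c2)cc1`, in this assay: 68400 nM

Three compounds share one core and differ only in the benzyl ether attached to the aniline ring. Compound 1 gives a weak inhibition number. Compound 2 sits at the limit of > 100000 nM in this assay, at which 1 of the 3 values shown sits, a boundary of the assay rather than a measured number. Compound 3, an isomer of compound 1, gives a weak number as well, and its value and that of compound 1 lie within the usual scatter of each other.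

Among the measured compounds shown here, the one measured single-point step is an at least 1.0-fold higher number from compound 1 to compound 2 (0.02 log units; that floor lies within the scatter); it stays within the scatter.

Compound 4, `O=[N+]([O-])c1ccc(COc2ccccc2Nc2ncnc3cc4c(cc23)OCCOCCO4)cc1`, differs from compound 2 by nitro in place of trifluoromethyl on an aromatic carbon. For the measured compounds named here, no measured pair exchanges trifluoromethyl for nitro, so the expectation rests on compound 2 standing at the limit and on the small step from compound 1. Compound 4 is therefore expected near the same weak region, at 90000 nM, with a likely range from 40000 nM to 200000 nM. The expected step is an at least 1.1-fold lower number from compound 2 to compound 4 (0.04 log units; that floor lies within the scatter).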

Compound 4, half-maximal inhibitory concentration: > 100000 nM
Compound 4: a limit, no number (the forecaster's own chance of this, stated with the estimate: 45%); middle value at least 1.1-fold (0.04 log units) from the limit.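

In this assay compound 4 gives > 100000 nM as a limit of the assay and not a number. Nitro in place of hydrogen gives an at least 1.0-fold higher number from compound 1 to compound 4 (0.02 log units; that floor lies within the scatter) and so, like trifluoromethyl, shows no readable gain in inhibition at this place on the benzyl ring, while the exchange of trifluoromethyl for nitro cannot be read, as both compounds stand at a limit. Two different groups at this one place now end at the same boundary, which has become common in this small set: the limit of > 100000 nM in this assay, at which 2 of the 4 values shown sit.

On these data alone, an amine or a carboxylic acid at this place might still give a measurable number, and that remains open. Also open, as far as these compounds go, is whether nitro or trifluoromethyl would act the same way on the benzyl ether of compound 3.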